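This account rests on a few compounds, and the source may have more. Where it says the series, first, only, none or still open, it means among the compounds named here.

Working notes on the series.

Of the compounds shown here, three share a common core and have been measured in an assay on cells for displacement of a labelled ligand from corticotropin-releasing factor receptor 1 (Homo sapiens), with a stated time of 100 min; on this read-out higher numbers stand for weaker inhibition and lower numbers for stronger inhibition. Compound 1 `C=C(C)CN(CC)Cc1c(C(F)(F)F)nc2n(-c3c(C)cc(C)cc3C)c(Cl)cn12` gives 67 nM in this assay. Compound 2 `Cc1cc(C)c(-n2c(Cl)cn3c(CN(CCC(F)(F)F)Cc4cccc(F)c4)c(C(F)(F)F)nc23)c(C)c1` gives 49 nM in this assay. Compound 3 `CCCCN(Cc1ccccc1)Cc1c(C(F)(F)F)nc2n(-c3c(C)cc(C)cc3C)c(Cl)cn12` gives 130 nM in this assay. Among these three numbers compound 1 stands second highest; its nearest neighbour is compound 2, and the gap between compound 1 and compound 2 lies within the scatter, as does the wider gap between compound 1 and compound 3. Nothing in these three values can therefore be read as a ranking.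

Compound 4 `Cc1cc(C)c(-n2c(Cl)cn3c(CN4CCC(C)CC4)c(C(F)(F)F)nc23)c(C)c1` has not yet been measured. It differs from compound 1 in one place: 4-methylpiperidin-1-yl in place of ethyl(2-methylprop-2-en-1-yl)amino on a saturated chain carbon bound to an aromatic carbon. The two have the same atoms, joined differently, so the change is from an open chain on the amine to a six-membered non-aromatic ring.

For the measured compounds named here, no measured pair isolates this change, so there is no step to lean on. The expectation is a modest shift in this assay, towards a higher number, of a size that may or may not exceed the scatter. The estimated step is a 1.8-fold higher number from compound 1 to compound 4 (0.25 log units; within the scatter). For compound 4 the expected value is 120 nM, with a range from 40 nM to 350 nM.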

Compound 4, inhibition constant: 3200 nM
The estimate for compound 4 lay 27-fold (1.43 log units) below the measured number, outside the stated range (above it).
By their numbers in this assay, from the lowest: compounds 2, 1 and 3 (each within the scatter of the next, the first and the last beyond it); then compound 4.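

The ring closure on the amine matters: in this assay, joining the same atoms as 4-methylpiperidin-1-yl rather than ethyl(2-methylprop-2-en-1-yl)amino gives a 48-fold higher number from compound 1 to compound 4 (1.68 log units; beyond the scatter), a large step beyond the scatter. The group on a saturated chain carbon bound to an aromatic carbon is therefore sensitive to how its atoms are joined, even with the atom counts unchanged and the counts of donors and acceptors the same. The earlier compounds, all with open-chain amines at this place and with no readable step among them, could not show this, and nothing available here speaks to the reason for the large step.

As far as these compounds go, it remains open whether the step belongs to ring closure as such or to the methyl group on the ring, a question that piperidin-1-yl itself, pyrrolidin-1-yl or morpholin-4-yl at the same place would address. Also open, from the compounds shown here alone, is whether a ring carrying a larger group, such as 4-benzylpiperidin-1-yl, would behave like compound 4 or return to the range of the open-chain amines.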